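The source may hold more compounds than are shown below. What is called first, only, known or untested is meant among the compounds shown, and "the series" means these compounds.

Measured so far:
Compound 1, `O=C1COc2ccc(-c3[nH]c(-c4ccc(C(F)(F)F)cc4)nc3-c3ccccc3)cc2N1`: 0.6%
Compound 2, `COc1ccc(-c2nc(-c3ccccc3)c(-c3ccc4c(c3)NC(=O)CO4)[nH]2)cc1`: 1.2%
Compound 3, `O=C1COc2ccc(-c3nn(-c4ccc(F)cc4)cc3-c3ccccc3)cc2N1`: 92.6%

In a functional assay on MV4-11 cells (Homo sapiens) for cytotoxicity, read by colorimetric assay and MTT assay, with a stated time of 3 days, tested at 20 uM (on this read-out higher numbers stand for a weaker effect at the one concentration tested and lower numbers for a stronger effect), compound 3 stands highest of the three numbers, and its gap to compound 2 and to compound 1 is far beyond the scatter, so compound 3 shows the weakest effect of the three. Compound 4, `O=C1COc2ccc(-c3nn(-c4ccccc4)cc3-c3ccccc3)cc2N1`, differs from compound 3 by one change, hydrogen in place of fluoro on an aromatic carbon: the 4-fluorophenyl becomes a phenyl. Among the measured compounds shown here, the only measured step, a number 0.6 percentage points higher from compound 1 to compound 2 (within the scatter), concerns a different group on a different core, so no measured step bears directly on this change. With nothing pointing either way, a step within the scatter is expected, a number 2.6 percentage points lower from compound 3 to compound 4 (within the scatter). Compound 4 is therefore estimated at 90%, with a range from 72% to 100%.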

Compound 4, a percentage reported as activity, at one concentration (the size of the read-out at that concentration, not a potency): 97.9%
Compound 4: the middle estimate sits 7.9 percentage points below what was measured, and the stated range covers the measured number.
By their numbers in this assay, from the lowest: compounds 1 and 2 (each within the scatter of the next); then compounds 3 and 4 (each within the scatter of the next).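

In this assay, swapping the fluoro for hydrogen on the ring carbon para to a large group gives a number 5.3 percentage points higher from compound 3 to compound 4 (within the scatter). On the core of compound 3, then, this single fluorine atom has no readable effect on the number, so the 4-fluorophenyl and the phenyl cannot be told apart here. No measurement at hand offers an explanation for this result.

The compounds shown leave open whether a larger or charged group at this same ring carbon, such as an amine or a carboxylic acid, would shift the read-out.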